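Compound 1 to compound 4: imidazolyl in place of phenyl

A few compounds are considered here, and "the series" means these few. Any claim that something is new, unique, unknown or untested is made for them only; others in the source may bear on it.

In a functional assay on CWR22R cells (Homo sapiens) for antiproliferative activity, read by CCK-8 assay, with a stated time of 6 days (on this read-out higher numbers stand for weaker inhibition and lower numbers for stronger inhibition), compound 1 (`CCN(c1cccc(-c2ccccc2)c1)c1ccc(C#N)c(Cl)c1`) has the entry "not determined" (no result reported) and so gives no number to start from. Compound 2 (`N#Cc1ccc(N2CCc3cc(-c4cnc5ccccc5c4)ccc32)cc1C(F)(F)F`) has the entry "not determined" (no result reported) and adds none either. In this assay compound 3 (`CCN(c1ccc(C#N)c(Cl)c1)c1cc(-c2ccccc2)ccc1C`) gives > 30000 nM as a limit of the assay and not a number. Among the measured compounds shown here, the only evidence near compound 1 is thus the limit of > 30000 nM in this assay, at which 1 of the 3 values shown sits, and no measured step exists.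

Compound 4 (`CCN(c1cccc(-n2ccnc2)c1)c1ccc(C#N)c(Cl)c1`) has not yet been measured. The structural change is 1H-imidazol-1-yl in place of phenyl on an aromatic carbon with 1H-imidazol-1-yl in place of phenyl on an aromatic carbon. Without a value for compound 1, the step itself cannot be read. Compound 3 at > 30000 nM, again a limit, is the sole reason for expecting a weak result. No step beyond the scatter is expected in this assay in either direction. The value expected for compound 4 is 20000 nM with an estimated range of 6000 nM to 30000 nM and a report of only a limit is about as likely as a number.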

Compound 4, half-maximal inhibitory concentration: > 30000 nM
Compound 4 ended at the assay's limit; the forecaster's own chance of this, stated with the estimate: 55%; middle value at least 1.5-fold (0.17 log units) from the limit.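

In this assay compound 4 gives > 30000 nM, a limit of the assay and not a number. Among the compounds shown here, no step between compound 1 and compound 4 can be read: neither carries a number. The compounds shown leave open whether 1H-imidazol-1-yl in place of phenyl changes antiproliferative activity at all.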